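The source may report more compounds than this note shows. Statements on the series, on what has been measured and on what is new or still open speak of the compounds shown alone.

For the measured compounds named here, in a functional assay on Jurkat cells (Homo sapiens) for antiproliferative activity, read by MTT assay (a higher number here means a weaker inhibitor, a lower number a stronger inhibitor), compound 2 (`COc1cc2c(cc1OC)C(=O)/C(=C/c1cc(C)c(N)c(C)c1)C2`) gives 55 nM as the lower of the two numbers measured so far, and compound 1 (`COc1cc2c(cc1OC)C(=O)/C(=C/c1cc(I)cc(I)c1O)C2`) gives 2500 nM on the shared core. Compound 3 (`CCOC(=O)COc1c(C)cc(/C=C2\Cc3cc(OC)c(OC)cc3C2=O)cc1C`), not yet measured, carries (ethoxycarbonyl)methoxy in place of amino on an aromatic carbon, ortho to two methyl groups and para to a large group ((ethoxycarbonyl)methoxy in place of amino on an aromatic carbon). Going by the values given here, no measured step shows what this exchange does in this assay on this core. A weaker inhibitor is expected, with the estimated change (an 11-fold higher number from compound 2 to compound 3 (1.04 log units; beyond the scatter)) beyond the scatter. Compound 3 is expected at 600 nM (estimated range 120 nM to 3000 nM).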

Compound 3, half-maximal inhibitory concentration: 2200 nM
Compound 3: middle estimate off by 3.7-fold (0.56 log units), on the low side, within the range that was stated.
By their numbers in this assay, from the lowest: compound 2; then compounds 3 and 1 (each within the scatter of the next).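

In this assay, for the compounds shown here, putting (ethoxycarbonyl)methoxy in place of amino on this aromatic carbon, ortho to two methyl groups, gives a 40-fold higher number from compound 2 to compound 3 (1.60 log units; beyond the scatter), the first measured exchange at this place on the shared core. The position is therefore not indifferent to what it carries, and this exchange costs much of the potency. Nothing measured accounts for the size of this step. The compounds shown leave open whether the loss follows from the oxygen link or from the ethyl ester chain. A hydroxyl, a methoxy group or the free carboxylic acid at this carbon would separate these.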